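From trifluoromethyl to chloro in compound 3

A few compounds are considered here, and "the series" means these few. Any claim that something is new, unique, unknown or untested is made for them only; others in the source may bear on it.

Compound 1 `N=C(NS(=O)(=O)c1ccccc1)N1CCN(c2cc3c(cc2F)c(=O)c(C(=O)O)cn3C2CC2)CC1`: 43 nM
Compound 2 `N=C(NS(=O)(=O)c1ccc(C(F)(F)F)cc1)N1CCN(c2cc3c(cc2F)c(=O)c(C(=O)O)cn3C2CC2)CC1`: 43 nM

In a functional assay on HL-60 cells (Homo sapiens) for antiproliferative activity, read by MTT assay, with a stated time of 72 h (a higher number here means a weaker inhibitor, a lower number a stronger inhibitor), compound 2 stands level with compound 1 at the digits shown. Compound 3 `N=C(NS(=O)(=O)c1ccc(Cl)cc1)N1CCN(c2cc3c(cc2F)c(=O)c(C(=O)O)cn3C2CC2)CC1` carries chloro in place of trifluoromethyl on an aromatic carbon, para to a large group: chloro in place of trifluoromethyl on an aromatic carbon. For the measured compounds named here, one measured step bears on this, trifluoromethyl in place of hydrogen on the same kind of carbon, and it gave no change at the digits printed from compound 1 to compound 2 (within the scatter). Going by the values given here, no chloro compound has been measured, so this step is the only guide, and no shift beyond the scatter is expected in this assay. The estimated step is no change at the digits printed from compound 2 to compound 3 (within the scatter). For compound 3 the expected value is 43 nM, with an estimated range of 22 nM to 85 nM.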

Compound 3, half-maximal inhibitory concentration: 43 nM
Estimate against measurement, compound 3: no gap at the digits printed, and the stated range covers the measured number.
By their numbers in this assay, from the lowest: compounds 1, 2 and 3 (each within the scatter of the next).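

In this assay chloro in place of trifluoromethyl gives no change at the digits printed from compound 2 to compound 3 (within the scatter) and chloro in place of hydrogen gives no change at the digits printed from compound 1 to compound 3 (within the scatter) on the same aromatic carbon, para to a large group. The earlier compounds shown here offered only one replacement of hydrogen at this position, whereas it has now taken two different groups with the reading level across all three compounds. No available measurement offers a reason for this. Going by these compounds, whether an amine, a methoxy group or a carboxylic acid on this carbon would also leave the reading level remains open. So does whether chloro on another carbon of this ring would do the same.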